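Trimming a Bicyclic Amine on a CXCR4 Antagonist Scaffold

The compounds below may be only part of what the source reports. "The series", "measured", "known", "first", "only" and "open" are said of these compounds alone.

Compound 1 `CN(C[C@H]1Cc2c(cccc2N2CCN(C3CC3)CC2)CN1)[C@H]1CCCc2cccnc21`: 23.5 nM
Compound 2 `CN(C[C@H]1Cc2c(cccc2N2CCN3CCC[C@@H]3C2)CN1)[C@H]1CCCc2cccnc21`: 3.59 nM

Among the compounds with values here, in a functional assay on CCRF-CEM cells for antagonist activity at C-X-C chemokine receptor type 4 (Homo sapiens), read by calcium flux, with stated times of 25 min and 90 s (a lower number here means a stronger inhibitor, a higher number a weaker inhibitor), compound 2 holds the lowest number of the two measured compounds, and the single measured step, a 6.5-fold lower number from compound 1 to compound 2 (0.82 log units; beyond the scatter), lies beyond the scatter. Compound 3 `CN(C[C@H]1Cc2c(cccc2N2C[C@@H]3C[C@H]2CN3)CN1)[C@H]1CCCc2cccnc21` differs from compound 2 by a group of 7 heavy atoms (5 carbon, 2 nitrogen; 2 five-membered non-aromatic rings with 1 hetero atom each) in place of a group of 9 heavy atoms (7 carbon, 2 nitrogen; one five-membered non-aromatic ring with 1 hetero atom, one six-membered non-aromatic ring with 2 hetero atoms), on an aromatic carbon. Within the data shown here, no measured step covers this particular exchange; the one known step replaced a different group at the same aromatic carbon, so it gives only a loose guide. The expected step of a 2.2-fold higher number from compound 2 to compound 3 (0.35 log units; beyond the scatter) is therefore small, with a slight lean toward a higher number. Compound 3 is estimated at 8 nM, within 2 nM to 30 nM.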

Compound 3, half-maximal inhibitory concentration: 146 nM
For compound 3 the middle estimate is 18-fold (1.26 log units) below the measured one, outside the stated range (above it).
By their numbers in this assay, from the lowest: compound 2; then compound 1; then compound 3.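

This aromatic carbon is far less forgiving than the first pair suggested: the new group brings a 41-fold higher number from compound 2 to compound 3 (1.61 log units; beyond the scatter) and also a 6.2-fold higher number from compound 1 to compound 3 (0.79 log units; beyond the scatter). The group with 2 five-membered non-aromatic rings, the only one here with a hydrogen-bond donor, therefore falls behind both groups containing a six-membered non-aromatic ring. Nothing available explains this loss.

Ring size, donor count and defined stereocentres all change together in this exchange, so the data cannot separate them. Going by these compounds, the effect of a methyl group on the donor nitrogen of the entering group remains open.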